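The compounds below may be only part of what the source reports. "The series", "measured", "known", "first", "only" and "open" are said of these compounds alone.

Working notes on the series.

Two members of this chalcone-type series carry the shared core and have been measured in an ADME assay on HEK293 cells (Homo sapiens) for antiproliferative activity, read by MTT assay, with a stated time of 24 h; a higher number here means a weaker inhibitor, a lower number a stronger inhibitor. Compound 1, `COc1ccc(C(=O)/C=C/c2cc(-c3ccc(OC)c(OC)c3)n3nc(-c4ccccc4)cc3n2)cc1OC`, gives 32500 nM in this assay. Compound 2, `COc1cc(-c2cc(C(=O)/C=C/c3ccc(Cl)cc3)nc3cc(-c4ccccc4)nn23)cc(OC)c1OC`, gives 53900 nM in this assay. The two numbers lie within the usual scatter of each other, so compound 1 and compound 2 cannot be separated on this assay; both sit in the weak range.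

Compound 3, `COc1ccc(-c2cc(/C=C/C(=O)c3ccc(C)c(C)c3)nc3cc(-c4ccccc4)nn23)cc1OC`, is not yet measured in this assay. Relative to compound 1 the change is 3,4-dimethylphenyl in place of 3,4-dimethoxyphenyl on a carbonyl carbon. Going by the values given here, no pair of measured compounds shows this change, so no step for it is known; the only guidance is that both measured compounds sit in the same weak range in this assay. The step from compound 1 to compound 3 is expected to be small, with no clear direction beyond the scatter, as a 1.1-fold higher number from compound 1 to compound 3 (0.03 log units; within the scatter). Compound 3 is therefore estimated at 35000 nM in this assay, with a range from 15000 nM to 90000 nM.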

Compound 3, half-maximal inhibitory concentration: 46200 nM
Estimate against measurement, compound 3: 1.3-fold (0.12 log units) below; low and high end bracket the measured number.
By their numbers in this assay, from the lowest: compounds 1, 3 and 2 (each within the scatter of the next).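

In this assay, going by these compounds alone, the replacement of 3,4-dimethoxyphenyl by 3,4-dimethylphenyl on a carbonyl carbon is a 1.4-fold higher number from compound 1 to compound 3 (0.15 log units; within the scatter) and gives the first step known for this position, where the earlier compounds offered only a shared weak range. The leaving group has 2 hydrogen-bond acceptors and the entering group has 0, yet compound 1 and compound 3 cannot be separated in this read-out, so this single exchange shows no dependence on those acceptors or on the methoxy oxygens at this position. No measurement on hand bears on the reason for this result.

The compounds shown leave open whether a phenyl group on the same carbonyl carbon carrying an amine or a carboxylic acid, or a longer chain in place of the phenyl group, would give a step beyond the scatter. They also leave open whether this exchange would read the same way on a shared core carrying something other than the 3,4-dimethoxyphenyl group of compound 1 and compound 3.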